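The source may hold more compounds than are shown below. What is called first, only, known or untested is meant among the compounds shown, and "the series" means these compounds.

Measured in an ADME assay on GM00637 cells (Homo sapiens) for cytotoxicity, read by MTT assay, with a stated time of 72 h; on this read-out higher numbers stand for weaker inhibition and lower numbers for stronger inhibition:
- Compound 1 `Nc1cc2nc(-c3ccccc3)nn(-c3ccccc3)c-2cc1=O`: 2040 nM
- Compound 2 `CNc1cc2nc(-c3ccccc3)nn(-c3ccccc3)c-2cc1=O`: 930 nM
- Compound 3 `O=c1cc2n(-c3ccccc3)nc(-c3ccccc3)nc-2cc1N1CCCC1`: 1790 nM

Compound 3 stands within the scatter of the other two values. The steps are a 1.1-fold lower number from compound 1 to compound 3 (0.06 log units; within the scatter) and a 1.9-fold higher number from compound 2 to compound 3 (0.28 log units; within the scatter). Only a 2.2-fold lower number from compound 1 to compound 2 (0.34 log units; beyond the scatter) goes beyond the scatter, and modestly.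

Compound 4 `CCOc1cc2nc(-c3ccccc3)nn(-c3ccccc3)c-2cc1=O` differs from compound 3 at one aromatic carbon: ethoxy in place of pyrrolidin-1-yl on an aromatic carbon. Within the data shown here, no measured step brings in ethoxy, so the evidence is indirect, resting on these three modest or smaller steps at that carbon. Taking compound 3 at 1790 nM as the anchor, no step beyond the scatter is expected in this assay. The estimated step is a 1.2-fold lower number from compound 3 to compound 4 (0.08 log units; within the scatter). For compound 4 the estimated value is 1500 nM, with an expected range of 650 nM to 3300 nM.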

Compound 4, half-maximal inhibitory concentration: > 5000 nM
Compound 4 gave a limit, no number; the forecaster's own chance of this, stated with the estimate: 2%; middle value at least 3.3-fold (0.52 log units) from the limit.
By their numbers in this assay, from the lowest: compounds 2, 3 and 1 (each within the scatter of the next, the first and the last beyond it). At a limit, above all of these: compound 4.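

In this assay compound 4 gives only a limit of the assay, not a number: the limit of > 5000 nM in this assay, at which 1 of the 4 values shown sits. Ethoxy in place of pyrrolidin-1-yl gives an at least 2.7-fold higher number from compound 3 to compound 4 (0.44 log units; beyond the scatter), in place of methylamino an at least 5.3-fold higher number from compound 2 to compound 4 (0.73 log units; beyond the scatter), and in place of amino an at least 2.4-fold higher number from compound 1 to compound 4 (0.38 log units; beyond the scatter). The nitrogen-linked groups at this aromatic carbon had produced nothing larger than a modest step, so this position proves able to move the number further than they showed.

A methoxy, a hydroxyl or a longer alkoxy chain at this carbon is not among the compounds shown, and whether the shift is particular to ethoxy stays open. From the compounds shown here alone, how far the true value of compound 4 lies past its limit also stays open.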